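Swapping the Cyclopropyl Ester: Outlook for Plasma Half-Life

The source may hold more compounds than are shown below. What is called first, only, known or untested is meant among the compounds shown, and "the series" means these compounds.

Compound 1 `CC(=O)Oc1ccccc1C(=O)O[C@H]1CO[C@H]2[C@@H]1OC[C@H]2OC(=O)C1CC1`: 0.015 h
Compound 2 `CCOc1cc(OCC)cc(C(=O)O[C@@H]2CO[C@H]3[C@@H]2OC[C@@H]3OC(=O)c2ccccc2OC(C)=O)c1`: 0.0283 h
Compound 3 `CC(=O)Oc1ccccc1C(=O)O[C@H]1CO[C@H]2[C@@H]1OC[C@H]2OC(=O)c1cnccc1Cl`: 0.0322 h

In an ADME assay on a cell-free system (plasma, Homo sapiens) for metabolic stability, with Plasma (Rattus norvegicus) as the target, read by HPLC, at pH 7.4 (a lower number here means that the compound disappears faster, a higher number that the compound lasts longer), compound 1 sits at the low end of the three numbers. Its gap to compound 2 is small a 1.9-fold higher number from compound 1 to compound 2 (0.28 log units; within the scatter), whereas the gap to compound 3 is modest yet real a 2.1-fold higher number from compound 1 to compound 3 (0.33 log units; beyond the scatter). Compound 4 `CC(=O)Oc1ccccc1C(=O)O[C@H]1CO[C@H]2[C@@H]1OC[C@H]2OC(=O)c1ccc(CO[N+](=O)[O-])cc1` differs from compound 1 in one place: 4-((nitrooxy)methyl)phenyl in place of cyclopropyl on a carbonyl carbon. The two steps that bear on this change both replace the cyclopropyl with an aromatic ring on the same carbonyl carbon, and both moved the number upward by roughly the same amount, one within the scatter and one just beyond it. A step of about that size is therefore expected for compound 4 a 2.0-fold higher number from compound 1 to compound 4 (0.30 log units; within the scatter). Compound 4 is thus estimated at 0.03 h, with a range from 0.015 h to 0.06 h.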

Compound 4, half-life: 0.04 h
Compound 4: middle estimate off by 1.3-fold (0.12 log units), on the low side; measured number inside the range.
By their numbers in this assay, from the lowest: compounds 1, 2, 3 and 4 (each within the scatter of the next, the first and the last beyond it).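

In this assay, the 4-((nitrooxy)methyl)phenyl group on this carbonyl carbon gives a 2.7-fold higher number from compound 1 to compound 4 (0.43 log units; beyond the scatter), the widest gap among the four compounds. Against the other two aromatic replacements it stands level, with a 1.2-fold higher number from compound 3 to compound 4 (0.09 log units; within the scatter) and a 1.4-fold higher number from compound 2 to compound 4 (0.15 log units; within the scatter). Replacing cyclopropyl with an aromatic ring thus gives a step beyond the scatter for compound 3 and compound 4, while compound 2 goes against this by staying within it.

Nothing available explains these steps. On these data alone, whether an amine or a carboxylic acid on the ring, or a longer chain in place of cyclopropyl, would lengthen the half-life further remains open.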